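This account rests on a few compounds, and the source may have more. Where it says the series, first, only, none or still open, it means among the compounds named here.

Measured compounds:
compound 1 `COc1cccc(-c2c(C)n(Cc3c(F)cccc3F)c(=O)n([C@H](C)CNCc3ccccc3)c2=O)c1`: 75 nM
compound 2 `COc1cccc(-c2c(C)n(Cc3c(F)cccc3F)c(=O)n([C@H](C)CNCC(C)C)c2=O)c1`: 190 nM

Compound 1 `COc1cccc(-c2c(C)n(Cc3c(F)cccc3F)c(=O)n([C@H](C)CNCc3ccccc3)c2=O)c1` holds the lowest of the two numbers measured in an assay on HEK293 cells for binding affinity to Gonadotropin-releasing hormone receptor (Homo sapiens) (on this read-out lower numbers stand for stronger inhibition and higher numbers for weaker inhibition), the nearest neighbour being compound 2 `COc1cccc(-c2c(C)n(Cc3c(F)cccc3F)c(=O)n([C@H](C)CNCC(C)C)c2=O)c1`, which in this assay gives 190 nM; the step of a 2.5-fold higher number from compound 1 to compound 2 (0.40 log units; beyond the scatter) is a modest one. Compound 3 `COc1ccc(CNC[C@@H](C)n2c(=O)c(-c3cccc(OC)c3)c(C)n(Cc3c(F)cccc3F)c2=O)cc1` is not yet measured. It differs from compound 1 by methoxy in place of hydrogen on an aromatic carbon, that is, the benzylamino group becomes a (4-methoxybenzyl)amino group on the saturated chain bound to the amine nitrogen. Going by the values given here, the only measured step, a 2.5-fold higher number from compound 1 to compound 2 (0.40 log units; beyond the scatter), concerns a different change, the swap of the phenyl for isopropyl, and says nothing directly about a substituent on the aromatic ring. Among the compounds with values here, with no comparable step in hand, the expected step of a 1.1-fold higher number from compound 1 to compound 3 (0.03 log units; within the scatter) is small and not beyond the scatter. Compound 3 is therefore estimated at 80 nM, within 35 nM to 200 nM.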

Compound 3, inhibition constant: 720 nM
Compound 3: the middle estimate sits 9.0-fold (0.95 log units) below what was measured; measured number outside the range, above it.
By their numbers in this assay, from the lowest: compound 1; then compound 2; then compound 3.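

In this assay, the aromatic ring of the benzylamino group does not tolerate every substitution, since methoxy in place of hydrogen on an aromatic carbon gives a 9.6-fold higher number from compound 1 to compound 3 (0.98 log units; beyond the scatter), beyond the scatter and numerically larger than the earlier 2.5-fold higher number from compound 1 to compound 2 (0.40 log units; beyond the scatter). An aromatic ring on this chain therefore does not by itself keep the number low: the (4-methoxybenzyl)amino group falls behind the isobutylamino-type chain of compound 2, with a 3.8-fold higher number from compound 2 to compound 3 (0.58 log units; beyond the scatter). Nothing available explains why the methoxy group has this effect.

The compounds shown carry only one substituent on this ring, at one place. On these data alone, whether a fluorine atom, a methyl group or a hydroxyl group there would bring a similar step, or whether methoxy elsewhere on the ring would, remains open.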